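Amide aryl swaps on a weakly antiproliferative anilide series

The source may hold more compounds than are shown below. What is called first, only, known or untested is meant among the compounds shown, and "the series" means these compounds.

Compound 3 `O=C(Nc1ccc(Cl)c(-c2nnc3c(Cl)cccn23)c1)c1ccc(Cl)cc1Cl` stands with two other analogues sharing its core and differing only in the aryl group on the carbonyl carbon. In a functional assay on HeLa cells (Homo sapiens) for antiproliferative activity, read by MTT assay, with a stated time of 72 h (on this read-out lower numbers stand for stronger inhibition and higher numbers for weaker inhibition), compound 3 gives only a limit, > 100000 nM. Compound 2 `CS(=O)(=O)c1ccc(C(=O)Nc2ccc(Cl)c(-c3nnc4c(Cl)cccn34)c2)cc1` likewise gives only a limit in this assay, > 100000 nM. Going by the values given here, compound 1 `O=C(Nc1ccc(Cl)c(-c2nnc3c(Cl)cccn23)c1)c1ccccn1` is the sole member with a number, 75500 nM in this assay. The two steps leading away from it are an at least 1.3-fold higher number from compound 1 to compound 2 (0.12 log units; that floor lies within the scatter) and an at least 1.3-fold higher number from compound 1 to compound 3 (0.12 log units; that floor lies within the scatter). The step that the two limits leave unreadable from compound 2 to compound 3 cannot be sized at all. Among the compounds with values here, the set is framed by the limit of > 100000 nM in this assay, at which 2 of the 3 values shown sit, so the series so far reads as inactive or nearly so.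

Compound 4 `O=C(Nc1ccc(Cl)c(-c2nnc3c(Cl)cccn23)c1)c1c(F)cccc1Cl` awaits measurement. The change is 2-chloro-6-fluorophenyl in place of 2,4-dichlorophenyl on a carbonyl carbon: ring size and heavy-atom count are kept, one chlorine is exchanged for a fluorine, and donor and acceptor counts stay at zero. Within the data shown here, none of the measured steps bears directly on such a halogen exchange; the steps from compound 1 into the limit region only say that these aryl amides do not gain potency. Compound 4 is therefore expected to sit near the limit, at 100000 nM in this assay. Its expected range runs from 40000 nM to 250000 nM. The step this estimate means, a number no higher from compound 3 to compound 4 (the limit leaves the size open), is expected to stay within the scatter, with a fair chance that only a limit is reported.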

Compound 4, half-maximal inhibitory concentration: > 100000 nM
Compound 4: only a limit was reported (the forecaster's own chance of this, stated with the estimate: 60%); the middle value lies on the limit itself.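

The 2-chloro-6-fluorophenyl group on this carbonyl carbon extends the series from aryl swaps to a halogen exchange within the same ring, and it also yields no number, so the limit now spans a third aryl group in this assay: the limit of > 100000 nM in this assay, at which 3 of the 4 values shown sit.

The steps from compound 2 and from compound 3 to compound 4 cannot be read, as both ends of each are limits. The one readable step is an at least 1.3-fold higher number from compound 1 to compound 4 (0.12 log units; that floor lies within the scatter), so compound 4 is not shown to lie beyond the scatter of compound 1.

From the compounds shown here alone, what an amine such as morpholine, a carboxylic acid on the aryl ring, or a longer chain in place of the aryl group would do on this carbonyl carbon stays open. Going by these compounds alone, also open is whether the pyridin-2-yl group of compound 1, the only member with a number at 75500 nM, differs from the other aryl groups by more than the scatter.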